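Biphenyl for hydroxy on the ketone aryl ring

A few compounds are considered here, and "the series" means these few. Any claim that something is new, unique, unknown or untested is made for them only; others in the source may bear on it.

Compound 1 `COc1cc(-c2nnc3n2NC(c2ccco2)C(C(=O)c2ccc(F)cc2)S3)cc(OC)c1OC`: 27700 nM
Compound 2 `COc1cc(-c2nnc3n2NC(c2ccco2)C(C(=O)c2ccc(C)cc2)S3)cc(OC)c1OC`: 7500 nM
Compound 3 `COc1cc(-c2nnc3n2NC(c2ccco2)C(C(=O)c2ccc(O)cc2)S3)cc(OC)c1OC`: 38300 nM

These three share one core and differ only in a single group on the ketone-bearing aromatic ring. In a functional assay on PC-3 cells (Homo sapiens) for cytotoxicity, read by MTT assay, with a stated time of 48 h (on this read-out lower numbers stand for stronger inhibition and higher numbers for weaker inhibition), compound 3 shows the highest number of the three, close to compound 1 and well apart from compound 2 (a 5.1-fold higher number from compound 2 to compound 3 (0.71 log units; beyond the scatter)). Compound 4 `COc1cc(-c2nnc3n2NC(c2ccco2)C(C(=O)c2ccc(-c4ccccc4)cc2)S3)cc(OC)c1OC` carries the change (phenyl in place of hydroxy on an aromatic carbon), para to a large group. Within the data shown here, two measured steps bear on it: a 3.7-fold lower number from compound 1 to compound 2 (0.57 log units; beyond the scatter) and a 5.1-fold higher number from compound 2 to compound 3 (0.71 log units; beyond the scatter), both showing that a carbon group at this place went with a lower number than fluoro or hydroxy. Among the measured compounds shown here, a lower number is therefore expected for compound 4, a 3.8-fold lower number from compound 3 to compound 4 (0.58 log units; beyond the scatter), of modest size, since phenyl is a far larger group than methyl and no measured step covers it directly. Compound 4 is estimated at 10000 nM, likely between 3000 nM and 35000 nM.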

Compound 4, half-maximal inhibitory concentration: 45900 nM
Compound 4: middle estimate off by 4.6-fold (0.66 log units), on the low side; the measured number lies above the stated range.
By their numbers in this assay, from the lowest: compound 2; then compounds 1, 3 and 4 (each within the scatter of the next).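

In this assay, a carbon group at this place does not by itself go with a low number: methyl and phenyl part clearly, with a 6.1-fold higher number from compound 2 to compound 4 (0.79 log units; beyond the scatter). Phenyl instead falls level with hydroxy and fluoro, with a 1.2-fold higher number from compound 3 to compound 4 (0.08 log units; within the scatter) and a 1.7-fold higher number from compound 1 to compound 4 (0.22 log units; within the scatter), so among these four only compound 2 stands apart. Nothing measured here gives a reason for this. Still open, from the compounds shown here alone, is whether a small chain such as ethyl, or an amine, at this place would group with compound 2 or with the other three.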